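Bromoenol lactones: removing the acetyl ester from compound 1

The source may hold more compounds than are shown below. What is called first, only, known or untested is meant among the compounds shown, and "the series" means these compounds.

Measured:
compound 1 `CCC[C@@H](OC(C)=O)C1=C(Br)/C(=C/Br)OC1=O` 1 ug/mL
compound 2 `CCC[C@@H](OC(C)=O)C1=C(Br)[C@@](CI)(OC)OC1=O` 7.1 ug/mL
compound 3 `CCC[C@@H](O)C1=C(Br)C(=C(Br)Br)OC1=O` 9.5 ug/mL

In a functional assay on KB cells (Homo sapiens) for cytotoxicity (a higher number here means that more compound is needed for the effect, a lower number that less compound is needed), compound 1 gives 1 ug/mL, the lowest of the three numbers; compound 2 and compound 3 both give higher numbers, the gap to each beyond the scatter, with compound 2 the nearer of the two. Compound 4 `CCC[C@@H](O)C1=C(Br)/C(=C/Br)OC1=O` is not yet measured. Relative to compound 1 its change is hydrogen in place of acetyl on an oxygen on a saturated carbon. No direct comparison of this exact change exists among the measured compounds; compound 3 carries the free hydroxy but also differs at the exocyclic position, so its number cannot be read as the effect of this change alone. The step of a 3.0-fold higher number from compound 1 to compound 4 (0.48 log units; beyond the scatter) is expected to be modest, toward a higher number, the data supporting nothing firmer. Compound 4 is estimated at 3 ug/mL, within 1 ug/mL to 10 ug/mL.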

Compound 4, concentration for half-maximal effect: 0.1 ug/mL
Compound 4: middle estimate off by 30-fold (1.48 log units), on the high side, and the stated range ends above it.
By their numbers in this assay, from the lowest: compound 4; then compound 1; then compounds 2 and 3 (each within the scatter of the next).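

In this assay, for the compounds shown here, the change from acetoxy to hydroxy gives a 10-fold lower number from compound 1 to compound 4 (1.00 log units; beyond the scatter) with the rest of the structure unchanged, the first reading of this change alone. At this position the acetyl is therefore not required for the effect, and the free hydroxy gives the lower number of the two groups. No measured evidence accounts for the step.

Open, on these data alone, is whether a methyl ether, a butyryl ester or an amine here would keep the lower number. Also open, as far as these compounds go, is whether the same change gives a similar step on the core of compound 3.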